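The source may report more compounds than this note shows. Statements on the series, on what has been measured and on what is new or still open speak of the compounds shown alone.

Measured so far:
Compound 1 `CCNC(=O)c1cc(Oc2ccc(NC(=O)c3cc4cccnc4n(-c4ccccc4)c3=O)cc2)ccn1` gives 220 nM in a functional assay on HT-29 cells (Homo sapiens) for antiproliferative activity, read by MTT assay, with a stated time of 72 h; a lower number here means a stronger inhibitor, a higher number a weaker inhibitor.
Compound 2 `CCNC(=O)c1cc(Oc2ccc(NC(=O)c3cc4cccnc4n(-c4ccc(F)cc4)c3=O)cc2)ccn1` gives 190 nM in this assay.
Compound 3 `CCNC(=O)c1cc(Oc2ccc(NC(=O)c3cc4cccnc4n(-c4ccc(Cl)cc4)c3=O)cc2)ccn1` gives 330 nM in this assay.

Compound 3 carries the highest of the three numbers, but its separation from the others is small: the steps of a 1.5-fold higher number from compound 1 to compound 3 (0.18 log units; within the scatter) and a 1.7-fold higher number from compound 2 to compound 3 (0.24 log units; within the scatter) both lie within the scatter, so the three compounds cannot be put in any order on these data.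

Compound 4 `CCNC(=O)c1cc(Oc2ccc(NC(=O)c3cc4cccnc4n(-c4ccc(Br)cc4)c3=O)cc2)ccn1` differs from compound 3 in one place: bromo in place of chloro on an aromatic carbon. For the measured compounds named here, the steps that bear on this change are the ones at the same aromatic carbon, where hydrogen, fluoro and chloro have already been compared. All of them were small: a 1.2-fold lower number from compound 1 to compound 2 (0.06 log units; within the scatter), a 1.5-fold higher number from compound 1 to compound 3 (0.18 log units; within the scatter) and a 1.7-fold higher number from compound 2 to compound 3 (0.24 log units; within the scatter), none beyond the scatter. Exchanging one halogen for another at this position has thus so far left this assay essentially unchanged, and no step in the data gives a reason to expect a different outcome for bromo.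

Compound 4 is therefore expected to give about 350 nM in this assay, with a range from 150 nM to 800 nM. Compound 4 is thus expected to show a 1.1-fold higher number from compound 3 to compound 4 (0.03 log units; within the scatter), a step that would stay within the scatter.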

Compound 4, half-maximal inhibitory concentration: 1160 nM
Compound 4: the middle estimate sits 3.3-fold (0.52 log units) below what was measured; the measured number lies above the stated range.
By their numbers in this assay, from the lowest: compounds 2, 1 and 3 (each within the scatter of the next); then compound 4.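

In this assay, for the compounds shown here, this position turns out not to be indifferent to the choice of halogen: going from 4-chlorophenyl to 4-bromophenyl gives a 3.5-fold higher number from compound 3 to compound 4 (0.55 log units; beyond the scatter) and is the first step at this aromatic carbon to pass beyond the scatter. Bromo also stands apart from the other two groups, with a 6.1-fold higher number from compound 2 to compound 4 (0.79 log units; beyond the scatter) and a 5.3-fold higher number from compound 1 to compound 4 (0.72 log units; beyond the scatter) as its steps, so hydrogen, fluoro and chloro remain a set that cannot be ordered while compound 4 lies clearly above all of them, and the earlier flat picture at this carbon holds only as far as chloro. Nothing measured here accounts for the change from chloro to bromo.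

The compounds shown leave open whether the higher number is particular to bromo or would recur with iodo, methyl or trifluoromethyl at the same carbon, and how an amine or a carboxylic acid there would read. They also leave open whether the same exchange of chloro for bromo would give a comparable step on a core other than the shared one.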